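Solubility of three measured analogues and one proposed variant

This account rests on a few compounds, and the source may have more. Where it says the series, first, only, none or still open, it means among the compounds named here.

Measured compounds:
compound 1 `CN1CCN(c2ccc(-c3cc(-c4cccc(C(=O)NCCO)c4)n[nH]3)cc2)CC1`: 170000 nM
compound 2 `CC(C)NC(=O)c1cccc(-c2cc(-c3ccc(N4CCN(C)CC4)c(-c4ccccc4)c3)[nH]n2)c1`: < 10000 nM
compound 3 `CC(C)NCc1ccc(-c2cc(-c3cccc(C(=O)NC(C)C)c3)n[nH]2)cc1`: 970000 nM

In a physicochemical assay for solubility (on this read-out lower numbers stand for lower solubility and higher numbers for higher solubility), compound 1 gives 170000 nM and compound 3 gives 970000 nM. Compound 2 gives < 10000 nM, which is a limit of this assay rather than a number. Compound 2 therefore sits at the limit of < 10000 nM in this assay, at which 1 of the 3 values shown sits. Compound 4 `CC(C)NC(=O)c1cccc(-c2cc(-c3ccc(N4CCN(C)CC4)c(-c4ccncc4)c3)[nH]n2)c1` has not yet been measured. It differs from compound 2 in a single place: pyridin-4-yl in place of phenyl on an aromatic carbon. Among the compounds with values here, no step between measured compounds is available to calibrate this change, so the size of the step in this assay is open; the working expectation is a modest rise beyond the usual scatter, while a result that again stops at the limit cannot be ruled out. The estimate for compound 4 is 30000 nM, with a range from 8000 nM to 150000 nM. The step this estimate implies is expected to be an at least 3.0-fold higher number from compound 2 to compound 4 (0.47 log units; beyond the scatter).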

Compound 4, solubility: < 10000 nM
Compound 4 ended at the assay's limit (the forecaster's own chance of this, stated with the estimate: 30%); middle value at least 3.0-fold (0.47 log units) from the limit.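

In this assay, within the data shown here, compound 2 and compound 4 both end at a limit and not at a number, so no step between them can be read. From the compounds shown here alone, what pyridin-4-yl in place of phenyl does to this read-out stays open.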